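A few compounds are considered here, and "the series" means these few. Any claim that something is new, unique, unknown or untested is made for them only; others in the source may bear on it.

Measured compounds:
Compound 1, `CCN(CC)CCCOc1ccc2cc(NC(=O)c3ccc(O)c(CC=C(C)C)c3)c(=O)oc2c1C`: 6390 nM in a functional assay on MCF7 cells (Homo sapiens) for antiproliferative activity; on this read-out lower numbers stand for stronger inhibition and higher numbers for weaker inhibition
Compound 2, `CC(C)=CCc1cc(C(=O)Nc2cc3ccc(OCCCN(C(C)C)C(C)C)c(C)c3oc2=O)ccc1O`: 1310 nM
Compound 3, `CC(C)=CCc1cc(C(=O)Nc2cc3ccc(OCCCNC(C)(C)C)c(C)c3oc2=O)ccc1O`: 950 nM

Compound 3 stands lowest of the three numbers in this assay; compound 2 lies nearest, and the two are within the scatter of each other, while compound 1 is furthest away.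

The step now followed leads from compound 3 to compound 4, `CC(C)=CCc1cc(C(=O)Nc2cc3ccc(OCCCN(C)Cc4ccccc4)c(C)c3oc2=O)ccc1O`. The change is: benzyl(methyl)amino in place of (tert-butyl)amino on a saturated chain carbon, three bonds along the chain from an oxygen on an aromatic ring

Going by the values given here, three measured steps bear on this position on the chain. The step of a 4.9-fold lower number from compound 1 to compound 2 (0.69 log units; beyond the scatter) and the step of a 6.7-fold lower number from compound 1 to compound 3 (0.83 log units; beyond the scatter) both lowered the number when diethylamino gave way to a bulkier amine, while the step of a 1.4-fold lower number from compound 2 to compound 3 (0.14 log units; within the scatter) stayed within the scatter. Among the compounds with values here, compound 4 carries a tertiary amine like compound 1 and compound 2, but with a benzyl group no measured compound holds, so there is no direct precedent for it. The account therefore expects compound 4 to land between compound 1 and compound 3, with a step of a 1.9-fold higher number from compound 3 to compound 4 (0.28 log units; within the scatter) regarded as plausible. For compound 4 the estimate in this assay is 1800 nM, within a range from 500 nM to 6500 nM.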

Compound 4, half-maximal inhibitory concentration: 11500 nM
Compound 4: the middle estimate sits 6.4-fold (0.81 log units) below what was measured; measured number outside the range, above it.
By their numbers in this assay, from the lowest: compounds 3 and 2 (each within the scatter of the next); then compounds 1 and 4 (each within the scatter of the next).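

In this assay, going by these compounds alone, the step of a 12-fold higher number from compound 3 to compound 4 (1.08 log units; beyond the scatter) and the step of an 8.8-fold higher number from compound 2 to compound 4 (0.94 log units; beyond the scatter) show that this amine at the end of the chain can push the number up as well as down, and the first of these is the only step at this position printed as large. The other new step, a 1.8-fold higher number from compound 1 to compound 4 (0.26 log units; within the scatter), places benzyl(methyl)amino alongside diethylamino, so that among the four compounds the amines fall into two groups: diisopropylamino and (tert-butyl)amino in one, diethylamino and benzyl(methyl)amino in the other. The missing amine hydrogen does not by itself sort these groups, since compound 2 has a tertiary amine like compound 4 yet stays with compound 3 within the scatter.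

Nothing available here explains why these amines separate as they do. On these data alone, it remains open whether the benzyl or the methyl group on the nitrogen drives the rise, and how benzylamino with its hydrogen kept, a piperidine, a morpholine or a longer chain would read in this assay.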